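The source may hold more compounds than are shown below. What is called first, only, known or untested is meant among the compounds shown, and "the series" means these compounds.

Measured so far in a functional assay on a cell-free system (Platelet, plasma, Oryctolagus cuniculus) for inhibition, with a stated time of 5 min; a higher number here means a weaker inhibitor, a lower number a stronger inhibitor:
- Compound 1 `CCOC(=O)/C=C/c1cc(Cl)ccc1OCc1nc(C)c(C)nc1C`: > 2000000 nM (a limit)
- Compound 2 `CCOC(=O)/C=C/c1cc(Br)cc(Br)c1OCc1nc(C)c(C)nc1C`: > 2000000 nM (a limit)
- Compound 3 `COc1cc(/C=C/C(=O)O)cc(OC)c1OCc1nc(C)c(C)nc1C`: 182000 nM

Compound 2 reads > 2000000 nM, which is a limit and not a number. It belongs to the limit of > 2000000 nM in this assay, at which 2 of the 3 values shown sit. Both compounds at that limit carry a 2-(ethoxycarbonyl)ethenyl group. Within the data shown here, compound 3 is the only measured compound with a 2-carboxyethenyl group and the only one to return a number, 182000 nM.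

Compound 4 `Cc1nc(C)c(COc2c(Br)cc(Br)cc2/C=C/C(=O)O)nc1C` follows from compound 2 with hydrogen in place of ethyl on an oxygen next to a carbonyl group, that is, ethoxycarbonyl to carboxy: hydrogen in place of ethyl on an oxygen next to a carbonyl group. Among the measured compounds shown here, no measured pair shows this change alone, and compound 3 also differs from compound 4 elsewhere on the shared core. The expectation therefore rests on a single reference, compound 3 at 182000 nM. A move towards stronger inhibition in this assay, beyond the usual scatter, is expected, though a reading at the limit remains possible. The expected size of the move is an at least 10-fold lower number from compound 2 to compound 4 (1.00 log units; beyond the scatter). For compound 4 the estimated value is 200000 nM, with an expected range of 40000 nM to 1000000 nM.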

Compound 4, half-maximal inhibitory concentration: 1310000 nM
The estimate for compound 4 lay 6.6-fold (0.82 log units) below the measured number; measured number outside the range, above it.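

On the 2-(ethoxycarbonyl)ethenyl group of compound 2, hydrogen in place of ethyl on an oxygen next to a carbonyl group yields a number rather than a limit: in this assay compound 4 gives 1310000 nM. This is the only pair shown that isolates the change from ethoxycarbonyl to carboxy, and it reads as an at least 1.5-fold lower number from compound 2 to compound 4 (0.18 log units; that floor lies within the scatter). The step is a floor and not a measured size, and it does not by itself establish a change beyond the scatter, because the reading for compound 2 is a limit: the limit of > 2000000 nM in this assay, at which 2 of the 4 values shown sit.

From the compounds shown here alone, the true size of the step remains open, as does whether the change from ethoxycarbonyl to carboxy behaves in the same way on the core of compound 1, where only an ester reading is available. Also open, going by these compounds, is whether another group in place of carboxy on the ethenyl chain, such as a primary amide or a hydroxymethyl group, would give a number in this assay on the core of compound 4.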